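Moving fluorine and carboxylic acid on the terminal ring

The compounds below may be only part of what the source reports. "The series", "measured", "known", "first", "only" and "open" are said of these compounds alone.

Measured so far in an assay on HEK293 cells for positive allosteric modulation of metabotropic glutamate receptor 3 (Rattus norvegicus), read by thallium flux, with a stated time of 2.5 min; a lower number here means a smaller maximal response, a higher number a larger maximal response:
compound 1 `Cc1c(OCCCCOc2ccc(C(=O)O)cc2)ccc(C(=O)CC(C)C)c1O` gives 51.9%
compound 2 `Cc1c(OCCCCOc2ccc(C(=O)O)cc2F)ccc(C(=O)CC2CCCC2)c1O` gives 31.2%
compound 3 `Cc1c(OCCCCOc2ccc(C(=O)O)cc2F)ccc(C(=O)CC(C)C)c1O` gives 67.7%

Compound 3 stands highest of the three numbers in this assay; the nearest step is a number 15.8 percentage points higher from compound 1 to compound 3 (beyond the scatter) and the furthest is a number 36.5 percentage points higher from compound 2 to compound 3 (beyond the scatter). Compound 4 `Cc1c(OCCCCOc2ccc(F)c(C(=O)O)c2)ccc(C(=O)CC(C)C)c1O` differs from compound 3 in one place: 3-carboxy-4-fluorophenyl in place of 4-carboxy-2-fluorophenyl on an oxygen on a saturated carbon. Among the compounds with values here, only one measured step touches this change, a number 15.8 percentage points higher from compound 1 to compound 3 (beyond the scatter), a modest rise on putting fluoro onto this ring. Within the data shown here, no measured pair shows both groups shifted to new positions, so the direction is uncertain, and a modest decrease is expected, a number 12.7 percentage points lower from compound 3 to compound 4 (beyond the scatter). Compound 4 is therefore estimated at 55%, with a range from 35% to 75%.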

Compound 4, largest response reached (reported as percent of maximum), in percent of the reference or control that the assay uses: 81.7%
Compound 4: the middle estimate sits 26.7 percentage points below what was measured, outside the stated range (above it).
By their numbers in this assay, from the lowest: compound 2; then compound 1; then compound 3; then compound 4.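

In this assay, replacing 4-carboxy-2-fluorophenyl with 3-carboxy-4-fluorophenyl gives a number 14 percentage points higher from compound 3 to compound 4 (beyond the scatter), so rearranging the same atoms on this ring is enough to change the maximal response. Against the unfluorinated 4-carboxyphenyl ring, the same ring gives a number 29.8 percentage points higher from compound 1 to compound 4 (beyond the scatter). Nothing measured here explains either rise.

The compounds shown leave open whether the shifted carboxylic acid or the shifted fluoro accounts for the rise, as 3-carboxyphenyl does not appear among them. They also leave open how a tetrazole in place of the carboxylic acid, or a longer chain between the two rings, would behave with this ring.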